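Trifluoromethoxy for Chloro: Expected Cytotoxicity of Compound 4

This account rests on a few compounds, and the source may have more. Where it says the series, first, only, none or still open, it means among the compounds named here.

Compound 2 `COc1cc2[nH]c(C)c(-c3ccc(Oc4ccc(Cl)cc4)cc3)c(=O)c2cc1Cl` was examined in an ADME assay on HepG2 cells (Homo sapiens) for cytotoxicity, read by resazurin assay, with a stated time of 24 h; on this read-out lower numbers stand for stronger inhibition and higher numbers for weaker inhibition. In this assay compound 2 returned only a limit, > 10000 nM. Compound 1 `Cc1[nH]c2ccc(F)cc2c(=O)c1-c1ccc(Oc2ccc(OC(F)(F)F)cc2)nc1` also gave a limit in this assay, > 10000 nM. Compound 3 `CCCCCCCc1c(C)nc2cc(OC)ccc2c1O` likewise sits at a limit in this assay, > 10000 nM. Nothing in these readings separates the three compounds from one another, since all of them rest at the limit of > 10000 nM in this assay, at which 3 of the 3 values shown sit.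

Compound 4 `COc1cc2[nH]c(C)c(-c3ccc(Oc4ccc(OC(F)(F)F)cc4)cc3)c(=O)c2cc1Cl` differs from compound 2 in one respect: trifluoromethoxy in place of chloro on an aromatic carbon. Among the compounds with values here, no pair of measured compounds differing in one place is available, so the size of such a change cannot be read from data here. Compound 1 carries the same trifluoromethoxy group on an aromatic carbon and gives only a limit in this assay. On that basis the step that the limit leaves unreadable from compound 2 to compound 4 is expected to be none beyond the scatter. Compound 4 is therefore estimated at 15000 nM, with a range from 5000 nM to 50000 nM, most likely again reported as a limit.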

Compound 4, half-maximal inhibitory concentration: > 10000 nM
Compound 4 was reported as a limit; the forecaster's own chance of this, stated with the estimate: 85%; the middle value lies beyond the limit too.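

Compound 2 and compound 4 both gave only a limit in this assay, so no step can be read between them: the limit of > 10000 nM in this assay, at which 4 of the 4 values shown sit. The compounds shown leave open whether trifluoromethoxy in place of chloro on an aromatic carbon changes this read-out at all.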